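This account rests on a few compounds, and the source may have more. Where it says the series, first, only, none or still open, it means among the compounds named here.

Compound 1 `O=C(/C=C/c1ccc([N+](=O)[O-])o1)c1ccc(Cl)cc1` and compound 2 `COc1ccc(COc2ccc(C(=O)/C=C/c3ccc([N+](=O)[O-])o3)cc2)cc1` share one core: a nitrofuran joined through a short unsaturated linker to a carbonyl that sits on an aromatic ring. They have been tested in a toxicity assay on Vero cells (Chlorocebus sabaeus) for cytotoxicity; on this read-out lower numbers stand for higher toxicity in this test and higher numbers for lower toxicity in this test. Compound 1 gives 558000 nM in this assay. Compound 2 gives 311000 nM in this assay. The gap between compound 2 and compound 1 lies within the scatter of this test, so the two numbers cannot be told apart and neither compound can be called the more toxic one.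

Compound 3 `O=C(/C=C/c1ccc([N+](=O)[O-])o1)c1ccc(OCc2cccc(Cl)c2)cc1` has not yet been measured. It differs from compound 2 in one place: 3-chlorophenyl in place of 4-methoxyphenyl on a saturated chain carbon bound to an oxygen on an aromatic ring. For the measured compounds named here, no step between measured compounds is known for such a swap, and compound 1 and compound 2 differ elsewhere, so there is nothing here to show how this exchange shifts the number. The expectation is therefore a step from compound 2 to compound 3 of a 1.2-fold lower number from compound 2 to compound 3 (0.09 log units; within the scatter), which is no more than the scatter itself. For compound 3 the estimate in this assay is 250000 nM, with a range from 100000 nM to 600000 nM.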

Compound 3, half-maximal cytotoxic concentration: 307000 nM
Compound 3: middle estimate off by 1.2-fold (0.09 log units), on the low side, and the stated range covers the measured number.
By their numbers in this assay, from the lowest: compounds 3, 2 and 1 (each within the scatter of the next).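

For the compounds shown here, replacing 4-methoxyphenyl with 3-chlorophenyl on a saturated chain carbon bound to an oxygen on an aromatic ring gives, in this assay, a 1.0-fold lower number from compound 2 to compound 3 (0.01 log units; within the scatter), the first readable step for this exchange, and it does not separate the two compounds. Placing (3-chlorobenzyl)oxy in place of chloro on an aromatic carbon gives a 1.8-fold lower number from compound 1 to compound 3 (0.26 log units; within the scatter), so even this exchange of a single chloro for a whole benzyl ether stays inside the scatter, and none of the three compounds can be ranked against the others in this test. Nothing available explains why these numbers stay so close together.

The swap changes both the ring's substituent and its place on the ring, so a 4-chlorophenyl or a 3-methoxyphenyl group would be needed to tell those two changes apart. On these data alone, it also remains open whether a benzyl group carrying an amine or a carboxylic acid, or a longer chain in place of the benzyl group, would move the number beyond the scatter.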